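Bromo-naphthyridine carboxamides: methoxy to trifluoromethyl on the benzyl

A few compounds are considered here, and "the series" means these few. Any claim that something is new, unique, unknown or untested is made for them only; others in the source may bear on it.

Compound 1 `COc1cccc(CNC(=O)c2nc(Br)c3cccnc3c2N[C@H]2CC[C@H](N)CC2)c1`: 7000 nM
Compound 2 `O=C(NCc1ccc(F)cc1)c1nc(Br)c2cccnc2c1NCc1ccccc1`: > 20000 nM
Compound 3 `C[C@@H](Nc1c(C(=O)NCc2ccc(F)cc2)nc(Br)c2cccnc12)c1ccccc1`: > 20000 nM

Among the compounds with values here, in a functional assay on MDA-MB-435 cells (Homo sapiens) for cytotoxicity, read by MTT assay, with a stated time of 72 h (a lower number here means a stronger inhibitor, a higher number a weaker inhibitor), compound 1 gives 7000 nM, the only number among the three measured compounds. Compound 2 reaches only a limit of the assay, > 20000 nM. Compound 3 likewise reaches only a limit, > 20000 nM. The step that the two limits leave unreadable from compound 2 to compound 3 therefore cannot be read, and the two limits are set out as the limit of > 20000 nM in this assay, at which 2 of the 3 values shown sit.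

Compound 4 `N[C@H]1CC[C@H](Nc2c(C(=O)NCc3cccc(C(F)(F)F)c3)nc(Br)c3cccnc23)CC1` differs from compound 1 in one place: trifluoromethyl in place of methoxy on an aromatic carbon. Within the data shown here, no measured step touches this position, so there is nothing in the three values that bears on the change itself; the one readable number belongs to compound 1, and the two limits say nothing about size. The expectation for compound 4 therefore rests on compound 1 alone, with a step of no change at the digits printed from compound 1 to compound 4 (within the scatter) expected to stay within the scatter. Compound 4 is estimated at 7000 nM in this assay, with a range from 2500 nM to 20000 nM.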

Compound 4, half-maximal inhibitory concentration: 4200 nM
The estimate for compound 4 lay 1.7-fold (0.22 log units) above the measured number; the measured number falls inside the stated range.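

Within the data shown here, changing 3-methoxybenzyl to 3-(trifluoromethyl)benzyl gives the first readable step at this position in this assay, namely a 1.7-fold lower number from compound 1 to compound 4 (0.22 log units; within the scatter). A group with one hydrogen-bond acceptor and a group with none, each on an aromatic carbon meta to a large group, therefore read alike within the usual scatter, although the entering group carries more heavy atoms. Compound 4 adds a second number to the set, while the step between the other two compounds still cannot be read and their values remain at a limit: the limit of > 20000 nM in this assay, at which 2 of the 4 values shown sit.

On these data alone, whether a group of another kind on this carbon, such as an amine, a carboxylic acid or a longer chain like ethoxy, would also stay within the scatter of compound 1 remains open. So does the reading for plain hydrogen there, with no substituent on that carbon at all.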